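Swapping Fluoro for Chloro on a Stilbene-like Series

The source may hold more compounds than are shown below. What is called first, only, known or untested is meant among the compounds shown, and "the series" means these compounds.

Compound 1 `CNc1ccc(/C=C/c2c(F)cccc2Cl)cc1`: 7.6 nM
Compound 2 `CNc1ccc(/C=C/c2c(Cl)cccc2Cl)cc1`: 50.1 nM
Compound 3 `CN(C)c1ccc(/C=C/c2c(F)cccc2Cl)nc1`: 20.4 nM

The values come from a functional assay on LS174T cells (Homo sapiens) for antiproliferative activity; on this read-out higher numbers stand for weaker inhibition and lower numbers for stronger inhibition. Compound 3 stands in the middle of the three numbers, clearly apart from both neighbours. Compound 4 `CN(C)c1ccc(/C=C/c2c(Cl)cccc2Cl)nc1` has not been measured. Its structure differs from that of compound 3 by one swap: chloro in place of fluoro on an aromatic carbon. Going by the values given here, only one measured step shows this same swap, chloro in place of fluoro on an aromatic carbon, though on a different core: a 6.6-fold higher number from compound 1 to compound 2 (0.82 log units; beyond the scatter). That step is beyond the scatter, so a higher number is expected here too, of similar or slightly smaller size, since one step is thin evidence. The estimated change is a 5.4-fold higher number from compound 3 to compound 4 (0.73 log units; beyond the scatter). For compound 4 the expected value is 110 nM, with an estimated range of 45 nM to 260 nM.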

Compound 4, half-maximal inhibitory concentration: 59.5 nM
For compound 4 the middle estimate is 1.8-fold (0.27 log units) above the measured one; the measured number falls inside the stated range.
By their numbers in this assay, from the lowest: compound 1; then compound 3; then compounds 2 and 4 (each within the scatter of the next).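

In this assay, chloro in place of fluoro gives a 2.9-fold higher number from compound 3 to compound 4 (0.46 log units; beyond the scatter), so the weaker inhibition seen with this change on the core of compound 1 also appears on a second core. The two steps point the same way, and their sizes cannot be told apart: the same change on two cores in this assay, a 6.6-fold higher number (0.82 log units; beyond the scatter) from compound 1 to compound 2 and a 2.9-fold higher number (0.46 log units; beyond the scatter) from compound 3 to compound 4, 2.3-fold (0.35 log units) apart, within the scatter of two such steps

Across both cores shown, the fluoro compound gives the lower number, and no pair goes against this. The compounds shown compare only fluoro and chloro at this position, so how a methoxy group, a nitrile or a plain hydrogen would fare there remains open.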